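This account rests on a few compounds, and the source may have more. Where it says the series, first, only, none or still open, it means among the compounds named here.

Compound 1 `CC(C)CN(CC(C)C)c1ccc(/C(=N/O)Nc2ccc(F)c(Br)c2)cc1NC(=O)NC1CCCCC1`: in an assay on isolated protein for inhibition of Indoleamine 2,3-dioxygenase 1 (Homo sapiens) (on this read-out higher numbers stand for weaker inhibition and lower numbers for stronger inhibition), compound 1 gives only a limit, > 3000 nM.
Compound 2 `CC(C)CN(CC(C)C)c1ccc(/C(=N/O)Nc2ccc(F)c(Br)c2)cc1NC(=O)Nc1ccc(Cl)cc1`: in this assay compound 2 gives 1490 nM.

Compound 2 holds the only true number shown; the other value is a limit. Among the measured compounds shown here, the single measured step, an at least 2.0-fold lower number from compound 1 to compound 2 (0.30 log units; that floor lies within the scatter), rests on that limit (the limit of > 3000 nM in this assay, at which 1 of the 2 values shown sits), so its real size is open. Compound 3 `CCCCNC(=O)Nc1cc(/C(=N/O)Nc2ccc(F)c(Br)c2)ccc1N(CC(C)C)CC(C)C` differs from compound 2 by butyl in place of 4-chlorophenyl on an amide-type nitrogen. Butyl, like the cyclohexyl of compound 1, is not aromatic. The step is therefore expected to run toward weaker inhibition, a 2.0-fold higher number from compound 2 to compound 3 (0.30 log units; within the scatter). Compound 3 is estimated at 3000 nM, within 1200 nM to 8000 nM.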

Compound 3, half-maximal inhibitory concentration: > 3000 nM
Compound 3: only a limit was reported; the forecaster's own chance of this, stated with the estimate: 50%; the middle value sits exactly at the limit.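

Butyl on this amide-type nitrogen, like cyclohexyl, leaves only a limit in this assay: the limit of > 3000 nM in this assay, at which 2 of the 3 values shown sit. So neither non-aromatic group shown gives a true number here, while 4-chlorophenyl does, and the change to butyl is an at least 2.0-fold higher number from compound 2 to compound 3 (0.30 log units; that floor lies within the scatter), which leaves its real size open. The step from cyclohexyl to butyl cannot be read: both of its values are limits.

From the compounds shown here alone, whether the ring or its chlorine carries the difference remains open. So does how a plain phenyl, a benzyl or a 4-methoxyphenyl on this nitrogen would read.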